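Dichlorophenyl amide variant of a triazolylthioacetamide series

The compounds below may be only part of what the source reports. "The series", "measured", "known", "first", "only" and "open" are said of these compounds alone.

Measured compounds:
- compound 1, `CN(C(=O)CCCCCCCSc1nnc(Cc2nn(C)c(=O)c3ccccc23)n1C)c1ccc(Cl)cc1Cl`: 11900 nM
- compound 2, `CC(C)COc1ccc(NC(=O)CSc2nnc(Cc3nn(C)c(=O)c4ccccc34)n2C)cc1`: 30000 nM

Both compounds were tested in an assay on isolated protein (Mus musculus) for inhibition of IL15-IL15 receptor (Homo sapiens), read by resazurin assay, with stated times of 30 min and 2.5 days; a higher number here means a weaker inhibitor, a lower number a stronger inhibitor. Of the two numbers, compound 2 has the highest, and its nearest neighbour is compound 1, whose number is lower by a margin beyond the scatter. Compound 3, `Cn1c(Cc2nn(C)c(=O)c3ccccc23)nnc1SCC(=O)Nc1ccc(Cl)cc1Cl`, has not yet been measured. It differs from compound 2 in one place: 2,4-dichlorophenyl in place of 4-(isobutoxy)phenyl on an amide-type nitrogen. Among the measured compounds shown here, compound 1 already carries the same 2,4-dichlorophenyl group, though on a different amide, so its value in this assay is the only pointer to what compound 3 might do. A modest step toward a lower number is expected from compound 2 to compound 3, a 2.0-fold lower number from compound 2 to compound 3 (0.30 log units; within the scatter), because compound 1 gives 11900 nM with that same ring. Compound 3 is therefore expected to give about 15000 nM, with a likely range from 5000 nM to 45000 nM.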

Compound 3, half-maximal inhibitory concentration: 17300 nM
The estimate for compound 3 lay 1.2-fold (0.06 log units) below the measured number; measured number inside the range.
By their numbers in this assay, from the lowest: compounds 1, 3 and 2 (each within the scatter of the next, the first and the last beyond it).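

In this assay the swap of 4-(isobutoxy)phenyl for 2,4-dichlorophenyl on the amide-type nitrogen gives a 1.7-fold lower number from compound 2 to compound 3 (0.24 log units; within the scatter) and so does not separate the two groups at this position. Among the compounds shown here, this is the first direct reading at this position: two aryl groups that differ in their substituents, one carrying oxygen and the other chlorine, cannot be told apart here, even though the group that enters is the smaller by heavy atoms. Nothing shown accounts for this result.

On these data alone, it remains open whether any group on this amide-type nitrogen can move the number beyond the scatter, for instance a phenyl ring bearing a carboxylic acid or an amine, or a plain alkyl chain in place of the ring. As far as these compounds go, the role of the shared core and of the thioacetamide link also remains open.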